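The source may report more compounds than this note shows. Statements on the series, on what has been measured and on what is new or still open speak of the compounds shown alone.

Three compounds have been measured in a functional assay on CCRF-CEM cells (Homo sapiens) for inhibition, read by MTT assay, with a stated time of 72 h; on this read-out lower numbers stand for stronger inhibition and higher numbers for weaker inhibition:

compound 1, `COc1cc(NC(C)CCCNC(=O)Nc2cccc(Cl)c2)c2ncccc2c1`, giving 22000 nM
compound 2, `COc1cc(NC(C)CCCNC(=O)NNC(=O)Nc2cccc(F)c2)c2ncccc2c1`, giving 98000 nM
compound 3, `COc1cc(NC(C)CCCNC(=O)Nc2cccc(C(F)(F)F)c2)c2ncccc2c1`, giving 19000 nM

Compound 1 holds the second highest of the three numbers. Its nearest neighbour is compound 3, which differs only by trifluoromethyl in place of chloro on an aromatic carbon, and that step a 1.2-fold lower number from compound 1 to compound 3 (0.06 log units; within the scatter) lies within the scatter. The furthest is compound 2, and the step of a 4.5-fold higher number from compound 1 to compound 2 (0.65 log units; beyond the scatter) lies beyond it.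

Compound 4, `COc1cc(NC(C)CCCNC(=O)NNC(=O)Nc2cccc(Cl)c2)c2ncccc2c1`, has not yet been measured in this assay. Compared with compound 1 the change is ((3-chlorophenyl)carbamoyl)amino in place of 3-chlorophenyl on an amide-type nitrogen. The step from compound 1 to compound 2 bears on this most directly, since it brings in the same carbamoylamino linkage and at the same time exchanges chloro for fluoro; it gave a 4.5-fold higher number from compound 1 to compound 2 (0.65 log units; beyond the scatter). The reverse step from compound 2 to compound 3 removes that linkage and gave a 5.2-fold lower number from compound 2 to compound 3 (0.71 log units; beyond the scatter). Because a 1.2-fold lower number from compound 1 to compound 3 (0.06 log units; within the scatter) shows the halogen exchange itself to matter little, the larger part of the step to compound 2 is attributed to the inserted linkage, and a comparable rise is expected for compound 4, estimated as a 3.6-fold higher number from compound 1 to compound 4 (0.56 log units; beyond the scatter). Compound 4 is therefore expected to give about 80000 nM, within a range of 40000 nM to 160000 nM.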

Compound 4, half-maximal inhibitory concentration: 81000 nM
Compound 4: the middle estimate sits 1.0-fold (0.01 log units) below what was measured; low and high end bracket the measured number.
By their numbers in this assay, from the lowest: compounds 3 and 1 (each within the scatter of the next); then compounds 4 and 2 (each within the scatter of the next).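

With the chlorine kept in place, the change from 3-chlorophenyl to ((3-chlorophenyl)carbamoyl)amino on the amide-type nitrogen can now be read on its own in this assay (a 3.7-fold higher number from compound 1 to compound 4 (0.57 log units; beyond the scatter)), whereas the earlier comparison of these two linkages also carried a change of halogen, and the same direction appears against the trifluoromethyl compound (a 4.3-fold higher number from compound 3 to compound 4 (0.63 log units; beyond the scatter)). The step between the two compounds carrying the longer linkage (a 1.2-fold lower number from compound 2 to compound 4 (0.08 log units; within the scatter)) shows that chloro in place of fluoro on an aromatic carbon does not separate them, so the halogen exchange lies within the scatter in this longer linkage as well as in the shorter one, and among these four compounds none goes against the split between the two linkages. Nothing available here gives a measured reason for the higher numbers that come with the carbamoylamino linkage.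

The compounds shown keep a halogen or trifluoromethyl on the aromatic ring, so it stays open how either linkage would behave with an amine or a carboxylic acid there, or with an unsubstituted phenyl. As far as these compounds go, it is also open whether the same rise would appear with a longer chain in place of the one in the shared core, or with a methyl group on the inserted nitrogen.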